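Configuration Change and Cytotoxicity on Mouse Macrophages

The compounds below may be only part of what the source reports. "The series", "measured", "known", "first", "only" and "open" are said of these compounds alone.

Compound 1: `O=C(S[C@]12CC[C@H](O)[C@H]1C(=O)NC2=O)c1ccc(O)cc1` — 1380000 nM
Compound 2: `CC(=O)S[C@@]12CC[C@H](O)[C@@H]1C(=O)NC2=O` — 559000 nM

Of the compounds shown here, two have been measured in an ADME assay on RAW264.7 cells (Mus musculus) for cytotoxicity, read by MTT assay, with a stated time of 24 h; on this read-out higher numbers stand for weaker inhibition and lower numbers for stronger inhibition. In this assay compound 1 gives 1380000 nM and compound 2 gives 559000 nM. Compound 2 holds the lowest of the two numbers, and the gap to compound 1 lies beyond the usual scatter, so compound 2 is the more strongly inhibiting of the pair.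

The next compound is compound 3, `CC(=O)S[C@]12CC[C@H](O)[C@H]1C(=O)NC2=O`. The change from compound 2 is this: the two compounds have the same atoms and bonds and differ only in configuration as drawn: 2 of 3 stereo elements differ; a stereocentre at a saturated ring carbon is drawn S in compound 2 and R in compound 3; a stereocentre at a saturated ring carbon is drawn R in compound 2 and S in compound 3. Going by the values given here, no step between measured compounds that differ in one place is available, so nothing in the measured data shows how a change of configuration alone plays out in this assay. The expectation for compound 3 is therefore a step from compound 2 of no size beyond the scatter, in either direction, that is a 1.1-fold higher number from compound 2 to compound 3 (0.03 log units; within the scatter). Compound 3 is accordingly estimated at 600000 nM, within a range from 250000 nM to 1400000 nM.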

Compound 3, half-maximal inhibitory concentration: 857000 nM
For compound 3 the middle estimate is 1.4-fold (0.15 log units) below the measured one; the range from low to high includes it.
By their numbers in this assay, from the lowest: compounds 2, 3 and 1 (each within the scatter of the next, the first and the last beyond it).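

In this assay, going by these compounds alone, compound 2 and compound 3 give the first direct reading of a change of configuration alone, and the comparison rests on one fact: the fact that compounds 2 and 3 differ only in the configuration as drawn. The two stereocentres drawn differently give a 1.5-fold higher number from compound 2 to compound 3 (0.19 log units; within the scatter), so at these two saturated ring carbons the change of configuration does not separate the compounds beyond the scatter. With the configuration held, methyl in place of 4-hydroxyphenyl on a carbonyl carbon gives a 1.6-fold lower number from compound 1 to compound 3 (0.21 log units; within the scatter), so this change does not separate the compounds beyond the scatter either.

What the compounds shown leave open is whether a longer chain or an amine on that carbonyl carbon would shift the number beyond the scatter. Also open, from the compounds shown here alone, is how the third stereo element, drawn alike in compound 2 and compound 3, would read if it alone were changed.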